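The source may hold more compounds than are shown below. What is called first, only, known or untested is meant among the compounds shown, and "the series" means these compounds.

Compound 1 `COc1cccc(OC)c1-c1cc(C(=O)N[C@@H](CCN2CCCCC2)CC(=O)NC2CC(F)(F)C2)nn1C1CCCC1` gives 0.633 h 
Compound 2 `COc1cccc(OC)c1-c1cc(C(=O)N[C@@H](CCN2CCCCC2)CC(=O)N(C)C2CCC2)nn1C1CCCC1` gives 0.617 h 
Compound 3 `COc1cccc(OC)c1-c1cc(C(=O)N[C@@H](CCN2CCCCC2)CC(=O)Nc2nccs2)nn1C1CCCC1` gives 0.45 h 

These values come from an ADME assay on microsomes from liver (Homo sapiens) for metabolic stability, read by LC-MS, using NADPH, with a stated time of 120 min, tested at 1 uM (a lower number here means that the compound disappears faster, a higher number that the compound lasts longer), and belong to three compounds that share one core and differ only in the group on the amide-type nitrogen or carbonyl carbon. With 0.45 h as its value, compound 3 stands within the scatter of both other compounds.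

Compound 4 `COc1cccc(OC)c1-c1cc(C(=O)N[C@@H](CCN2CCCCC2)CC(=O)Nc2nnn[nH]2)nn1C1CCCC1` keeps the structure of compound 3 except for one change: 1H-tetrazol-5-yl in place of 1,3-thiazol-2-yl on an amide-type nitrogen.

Three measured steps changed this same part of the molecule: (a 1.4-fold lower number from compound 1 to compound 3 (0.15 log units; within the scatter)), (a 1.4-fold lower number from compound 2 to compound 3 (0.14 log units; within the scatter)) and (a 1.0-fold lower number from compound 1 to compound 2 (0.01 log units; within the scatter)). All three are small and lie within the scatter, so varying this group has so far left the half-life in this assay almost unmoved. However, none of the measured compounds carries a 1H-tetrazol-5-yl group, so the data offer no direct precedent and the range has to stay wide.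

The expected step is therefore none beyond the scatter (a 1.4-fold higher number from compound 3 to compound 4 (0.16 log units; within the scatter)). For compound 4 the estimated half-life is 0.65 h within an expected range from 0.3 h to 1.5 h in this measurement.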

Compound 4, half-life: 0.403 h
Compound 4: the middle estimate sits 1.6-fold (0.21 log units) above what was measured; low and high end bracket the measured number.
By their numbers in this assay, from the lowest: compounds 4, 3, 2 and 1 (each within the scatter of the next).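

Placing 1H-tetrazol-5-yl on the amide-type nitrogen in place of 1,3-thiazol-2-yl swaps one five-membered aromatic ring for another that has more hetero atoms and a hydrogen-bond donor, yet in this assay this leaves the half-life within the scatter (a 1.1-fold lower number from compound 3 to compound 4 (0.05 log units; within the scatter)). The comparisons with the two non-aromatic groups are also within the scatter (a 1.5-fold lower number from compound 2 to compound 4 (0.18 log units; within the scatter); a 1.6-fold lower number from compound 1 to compound 4 (0.20 log units; within the scatter)), so all four compounds shown now agree, with none going against the pattern, that the half-life stays almost unchanged when this group is varied, even when the group itself carries a hydrogen-bond donor. Nothing available here explains why the half-life changes so little at this position.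

The compounds shown still leave open whether this holds for quite different groups at this place, such as a simple primary amine or a carboxylic acid carried on a longer chain. All four also share the same core, so how the half-life responds to a change elsewhere in the molecule remains an open question.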